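The source may report more compounds than this note shows. Statements on the series, on what has been measured and on what is new or still open speak of the compounds shown alone.

Of the compounds shown here, three built on one shared core have been measured in a functional assay on PC-3 cells (Homo sapiens) for cytotoxicity, read by sulforhodamine B assay, with a stated time of 72 h; on this read-out lower numbers stand for stronger inhibition of growth and higher numbers for weaker inhibition of growth. Compound 1 `O=C(Nc1cc(C(F)(F)F)cc(C(F)(F)F)c1)C1CCc2ccccc2N1C(=O)c1ccccc1Cl` gives 8040 nM in this assay. Compound 2 `O=C(Nc1ccccc1O)C1CCc2ccccc2N1C(=O)c1ccccc1Cl` gives 60000 nM. Compound 3 `O=C(Nc1ccccc1C(F)(F)F)C1CCc2ccccc2N1` gives 53300 nM. Compound 1 therefore shows the lowest number of the three, and both of the other two compounds lie beyond the usual scatter from it, so among this small set it is the most potent inhibitor of growth.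

Compound 4 `CCCCCCCCC(=O)N1c2ccccc2CCC1C(=O)Nc1cc(C(F)(F)F)cc(C(F)(F)F)c1` has not yet been measured. It differs from compound 1 in one place: octyl in place of 2-chlorophenyl on a carbonyl carbon. For the measured compounds named here, no measured pair shows this kind of exchange, and compound 2 and compound 3 each differ from compound 1 elsewhere, so nothing measured here speaks directly to what this swap does. The expected change is modest, a 1.5-fold higher number from compound 1 to compound 4 (0.17 log units; within the scatter), leaning toward a somewhat higher number with wide uncertainty. Compound 4 is accordingly estimated at 12000 nM in this assay, with a plausible range from 3000 nM to 50000 nM.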

Compound 4, concentration for 50% growth inhibition: 7430 nM
Compound 4: middle estimate off by 1.6-fold (0.21 log units), on the high side, within the range that was stated.
By their numbers in this assay, from the lowest: compounds 4 and 1 (each within the scatter of the next); then compounds 3 and 2 (each within the scatter of the next).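

In this assay, octyl in place of 2-chlorophenyl on a carbonyl carbon gives a 1.1-fold lower number from compound 1 to compound 4 (0.03 log units; within the scatter) and so makes no readable difference. For the compounds shown here, this is the first direct look at this position: on a carbonyl carbon whose other neighbours are an amide-type nitrogen in a ring, an open eight-carbon chain and a chlorine-bearing aromatic ring cannot be told apart in this read-out. No measurement here accounts for this match.

On these data alone, whether a shorter chain such as butyl, a longer chain such as dodecyl, or a chain ending in an amine or a carboxylic acid would also read alike at this position remains open. So does whether the same exchange would read alike in compound 2, which carries a different group on its other amide.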